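A Same-Size Swap at One Amino Group

The source may report more compounds than this note shows. Statements on the series, on what has been measured and on what is new or still open speak of the compounds shown alone.

Two measured compounds set the scale in an ADME assay on the whole organism for inhibition, with Echinochloa crus-galli var. formosensis as the target, with a stated time of 4 days; a lower number here means a stronger inhibitor, a higher number a weaker inhibitor. Compound 1 (`CCN(CC)c1nc(Cl)nc(N[C@H](C)c2ccccc2)n1`) gives 24000 nM, and compound 2 (`CC[C@@H](C)Nc1nc(Cl)nc(N[C@@H](C)c2ccccc2)n1`) gives 7410 nM. Compound 2 therefore has the lower number of the two, a gap beyond the usual scatter of repeat measurements, which makes it the stronger inhibitor of this pair.

Compound 3 (`CCN(CC)c1nc(Cl)nc(N[C@@H](C)c2ccccc2)n1`) departs from compound 2 at a single place: diethylamino in place of (sec-butyl)amino on an aromatic carbon. Diethylamino stands in place of (sec-butyl)amino on an aromatic carbon, and the two compounds have the same atoms, joined differently.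

Going by the values given here, no measured pair isolates this swap, so any forecast is tentative. Among the compounds with values here, the only guide is compound 1, the one measured compound that carries diethylamino, at 24000 nM. On that basis, the expected change is a 3.4-fold higher number from compound 2 to compound 3 (0.53 log units; beyond the scatter), in the direction of weaker inhibition. For compound 3 the estimated value is 25000 nM, with an expected range from 8000 nM to 80000 nM.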

Compound 3, half-maximal inhibitory concentration: 257 nM
Estimate against measurement, compound 3: 97-fold (1.99 log units) above, outside the stated range (below it).
By their numbers in this assay, from the lowest: compound 3; then compound 2; then compound 1.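

In this assay, diethylamino in place of (sec-butyl)amino gives a 29-fold lower number from compound 2 to compound 3 (1.46 log units; beyond the scatter), so at this position, on an aromatic carbon between two ring nitrogen atoms, the way the same atoms are joined matters far more than the opening pair suggested. The swap changes two counted features at once: the group that leaves has one hydrogen-bond donor and one defined stereocentre, while diethylamino has neither, and this single step cannot separate the two. Diethylamino also appears in both the highest and the lowest number so far, with a 93-fold lower number from compound 1 to compound 3 (1.97 log units; beyond the scatter), and this large step comes from the stereocentre at the saturated chain carbon alone: the fact that compounds 1 and 3 differ only in the configuration as drawn

On these data alone, what remains open is whether the configuration of the sec-butyl stereocentre has any bearing on the number, as only one drawn form of that group appears here, and whether the preferred configuration at the saturated chain carbon would hold with (sec-butyl)amino on the core as well. As far as these compounds go, it is also open how a smaller dimethylamino group or a longer dipropylamino group would behave at this position.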